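Swapping the benzyl aryl group on a shared triazole-thioether core

The source may report more compounds than this note shows. Statements on the series, on what has been measured and on what is new or still open speak of the compounds shown alone.

Measured compounds:
- compound 1, `Clc1ccccc1CSc1nnc(-c2ccncc2)n1-c1ccccc1`: 15700 nM
- compound 2, `Fc1ccc(CSc2nnc(-c3ccncc3)n2-c2ccccc2)cc1`: 15600 nM
- compound 3, `Brc1ccc(CSc2nnc(-c3ccncc3)n2-c2ccccc2)cc1`: 12900 nM

All three share the same core and differ only in the aromatic ring attached to the saturated chain carbon bound to a sulfur. In a functional assay on HepG2 cells (Homo sapiens) for inhibition, read by MTT assay, with a stated time of 48 h (a higher number here means a weaker inhibitor, a lower number a stronger inhibitor), compound 3 gives the lowest of the three numbers, but this standing is slight: the step of a 1.2-fold lower number from compound 1 to compound 3 (0.09 log units; within the scatter) and the step of a 1.2-fold lower number from compound 2 to compound 3 (0.08 log units; within the scatter) both lie within the scatter, as does the step of a 1.0-fold lower number from compound 1 to compound 2 (0.00 log units; within the scatter) between the other two. Taken together, these three steps show that exchanging one halogenated phenyl ring for another at this place has not moved the numbers beyond what repeated measurements would show.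

Compound 4, `O=[N+]([O-])c1ccccc1CSc1nnc(-c2ccncc2)n1-c1ccccc1`, has not yet been measured. It differs from compound 3 by 2-nitrophenyl in place of 4-bromophenyl on a saturated chain carbon bound to a sulfur. Among the compounds with values here, no measured step involves a nitrophenyl group here, so the only guide is that earlier changes at this place stayed within the scatter. The step of a 1.1-fold higher number from compound 3 to compound 4 (0.04 log units; within the scatter) is therefore expected to be small, with no clear direction. Compound 4 is estimated at 14000 nM in this assay, with a range from 6000 nM to 35000 nM that allows for the unfamiliar group.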

Compound 4, half-maximal inhibitory concentration: > 50000 nM
Compound 4: only a limit was reported; the forecaster's own chance of this, stated with the estimate: 10%; middle value at least 3.5-fold (0.55 log units) from the limit.
By their numbers in this assay, from the lowest: compounds 3, 2 and 1 (each within the scatter of the next). At a limit, above all of these: compound 4.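

In this assay this position no longer looks indifferent to what its ring carries: the halogenated rings stayed within the scatter of one another, but 2-nitrophenyl gives an at least 3.8-fold higher number from compound 3 to compound 4 (0.58 log units; beyond the scatter) and an at least 3.2-fold higher number from compound 2 to compound 4 (0.50 log units; beyond the scatter) when it replaces them. The closest comparison is nitro in place of chloro on an aromatic carbon, which gives an at least 3.1-fold higher number from compound 1 to compound 4 (0.50 log units; beyond the scatter) and shows that changing this single group on the ring is enough to carry the number beyond the scatter. Going by these compounds, the figure for compound 4 is a limit of the assay and not a number, so these steps give only a smallest possible size and the true value stays unknown: the limit of > 50000 nM in this assay, at which 1 of the 4 values shown sits.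

On these data alone, what remains open is whether this large step belongs to nitro alone, which an amine or a carboxylic acid in place of nitro on the same ring could help to show. Also open, as far as these compounds go, is whether a methoxy group on the ring, or a longer chain between the ring and the sulfur, would leave the number close to those of the halogenated rings.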